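The source may report more compounds than this note shows. Statements on the series, on what has been measured and on what is new or still open speak of the compounds shown alone.

Measured so far, in a functional assay on HepG2 cells (Homo sapiens) for inhibition, read by MTT assay, with a stated time of 48 h; a lower number here means a stronger inhibitor, a higher number a weaker inhibitor:

compound 1 `Fc1ccc(/C=N/Nc2nc(-c3ccc(C(F)(F)F)cc3)cs2)cc1F` gives 14500 nM
compound 2 `Fc1ccc(/C=N/Nc2nc(-c3cc(C(F)(F)F)cc(C(F)(F)F)c3)cs2)cc1F` gives 16700 nM
compound 3 `COc1cc(/C=N/Nc2nc(-c3ccc(C(F)(F)F)cc3)cs2)c(Br)c(Br)c1OC` gives > 100000 nM

The value for compound 3 is a limit of this assay and not a number; compound 3 stands at the limit of > 100000 nM in this assay, at which 1 of the 3 values shown sits, so this assay gives only a ceiling for it.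

Compound 4 `COc1ccccc1-c1csc(N/N=C/c2cc(OC)c(OC)c(Br)c2Br)n1` is not yet measured. It differs from compound 3 by 2-methoxyphenyl in place of 4-(trifluoromethyl)phenyl on an aromatic carbon, while the rest of the molecule stays as in compound 3. Among the compounds with values here, no pair of measured compounds isolates this change, so no step size is known for it. Given that compound 3 sits at the limit, compound 4 is expected to stay near it as well, with the step of a number no higher from compound 3 to compound 4 (the limit leaves the size open) expected to lie within the scatter. In this assay compound 4 is estimated at 100000 nM, between 30000 nM and 300000 nM.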

Compound 4, half-maximal inhibitory concentration: > 100000 nM
Compound 4: only a limit was reported (the forecaster's own chance of this, stated with the estimate: 70%); the middle value lies on the limit itself.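

In this assay compound 3 and compound 4 both rest on limits, so no step can be read between them: the limit of > 100000 nM in this assay, at which 2 of the 4 values shown sit.

On these data alone, whether 2-methoxyphenyl in place of 4-(trifluoromethyl)phenyl changes inhibition at all remains open.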